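The source may hold more compounds than are shown below. What is called first, only, known or untested is meant among the compounds shown, and "the series" means these compounds.

In a functional assay on HepG2 cells (Homo sapiens) for inhibition, read by MTT assay, with a stated time of 72 h (a higher number here means a weaker inhibitor, a lower number a stronger inhibitor), the three measured compounds gave these numbers:

Compound 1, `Cc1cccc(-n2cc(COc3cccc(NC(=O)Nc4ccc(Cl)c(C(F)(F)F)c4)c3)nn2)c1`: 7270 nM
Compound 2, `N#Cc1ccc(-n2cc(COc3cccc(NC(=O)Nc4ccc(Cl)c(C(F)(F)F)c4)c3)nn2)cc1`: 2980 nM
Compound 3, `O=C(Nc1cccc(OCc2cn(-c3cccc(Cl)c3)nn2)c1)Nc1ccc(Cl)c(C(F)(F)F)c1`: 2020 nM

Among these three numbers compound 2 stands second highest. Its nearest neighbour is reached by a 1.5-fold lower number from compound 2 to compound 3 (0.17 log units; within the scatter), a step within the scatter; its furthest neighbour by a 2.4-fold lower number from compound 1 to compound 2 (0.39 log units; beyond the scatter), a modest step beyond it.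

Compound 4, `O=C(Nc1cccc(OCc2cn(-c3ccc(Cl)cc3)nn2)c1)Nc1ccc(Cl)c(C(F)(F)F)c1`, differs from compound 2 in one place: chloro in place of cyano on an aromatic carbon. Going by the values given here, two measured steps bear on this. The first, a 1.5-fold lower number from compound 2 to compound 3 (0.17 log units; within the scatter), removed the same cyano group from the same ring while a chloro entered at another position, and the number hardly moved. The second, a 3.6-fold lower number from compound 1 to compound 3 (0.56 log units; beyond the scatter), brought a chloro onto an aromatic carbon in place of methyl and gave a modest lowering. Taken together, a chloro in place of cyano is expected to leave this assay roughly where compound 2 sits, with at most a small move towards a lower number.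

Compound 4 is therefore estimated at 2500 nM, with a range from 1200 nM to 5500 nM. The expected step is a 1.2-fold lower number from compound 2 to compound 4 (0.08 log units; within the scatter), which is not beyond the scatter.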

Compound 4, half-maximal inhibitory concentration: 2490 nM
Estimate against measurement, compound 4: 1.0-fold (0.00 log units) above; measured number inside the range.
By their numbers in this assay, from the lowest: compounds 3, 4 and 2 (each within the scatter of the next); then compound 1.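

In this assay, the direct exchange of 4-cyanophenyl for 4-chlorophenyl gives a 1.2-fold lower number from compound 2 to compound 4 (0.08 log units; within the scatter), so at this position the nitrile and the chloro cannot be told apart, a comparison that compound 3 could not give cleanly, since its 3-chlorophenyl changed the group and its place together. Shifting the chloro gives a 1.2-fold higher number from compound 3 to compound 4 (0.09 log units; within the scatter), so these two placings cannot be told apart either, whereas a 2.9-fold lower number from compound 1 to compound 4 (0.47 log units; beyond the scatter) shows 4-chlorophenyl standing apart from the 3-methylphenyl group. No measurement offers a reason for any of these steps.

From the compounds shown here alone, it remains open whether an amine or a carboxylic acid on this ring would stay level with the chloro and nitrile compounds. A 4-methylphenyl group would also show whether the weaker result of compound 1 belongs to the methyl itself or to its place.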